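The compounds below may be only part of what the source reports. "The series", "measured", "known", "first", "only" and "open" are said of these compounds alone.

Measured compounds:
compound 1 `COc1ccc(/C=C/C(=O)c2ccc(OC)c3c2OC(C)(C)C=C3)c(F)c1` — > 10000 nM
compound 2 `COc1ccc(C(=O)/C=C/c2ccc(N(c3ccccc3)c3ccccc3)cc2)c2c1C=CC(C)(C)O2` — > 10000 nM
compound 3 `COc1ccc(C(=O)/C=C/c2ccc(-n3ccnc3)cc2)c2c1C=CC(C)(C)O2` — > 10000 nM

In a functional assay on HCT-116 cells (Homo sapiens) for antiproliferative activity, read by MTT assay, with a stated time of 24 h (a higher number here means a weaker inhibitor, a lower number a stronger inhibitor), compound 1 gives > 10000 nM, which is a limit of the assay and not a number. Compound 2 likewise gives only the limit > 10000 nM. Compound 3 also gives only the limit > 10000 nM. So compound 1 stands nowhere in particular among these values: all three sit at the limit of > 10000 nM in this assay, at which 3 of the 3 values shown sit, and no step between any two of them can be sized.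

The unmeasured compound 4 `COc1ccc(C(=O)/C=C/c2cccc([N+](=O)[O-])c2)c2c1C=CC(C)(C)O2` differs from compound 1 in one place: 3-nitrophenyl in place of 2-fluoro-4-methoxyphenyl on a double-bonded chain carbon bound to a double-bonded chain carbon. With no measured step to lean on and every shown value at the limit, the step from compound 1 to compound 4 is expected to be none beyond the scatter, with a step that the limit leaves unreadable from compound 1 to compound 4 as the best guess. Compound 4 is therefore estimated at 15000 nM in this assay, with a range from 5000 nM to 50000 nM, and most likely it too will be reported only as a limit.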

Compound 4, half-maximal inhibitory concentration: 8050 nM
Compound 4: the middle estimate sits 1.9-fold (0.27 log units) above what was measured; measured number inside the range.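

In this assay compound 4 gives 8050 nM, the first value among the compounds shown that is a number and not a limit. Compound 1 gives > 10000 nM, which is a limit of the assay and not a number. On these data alone, with 3-nitrophenyl in place of 2-fluoro-4-methoxyphenyl on a double-bonded chain carbon bound to a double-bonded chain carbon, the data give an at least 1.2-fold lower number from compound 1 to compound 4 (0.09 log units; that floor lies within the scatter), so this change can be read only as a floor and its true size remains unknown.

The steps among compound 1, compound 2 and compound 3 cannot be read, and most of the set gives no number to compare: the limit of > 10000 nM in this assay, at which 3 of the 4 values shown sit. As far as these compounds go, whether a phenyl ring bearing an amine or a carboxylic acid at this place would give a value further from the limit remains open.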